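The source may report more compounds than this note shows. Statements on the series, on what has been measured and on what is new or still open speak of the compounds shown alone.

Measured so far:
compound 1, `Cc1nccn1-c1cnc(NCc2c(F)ccc3c2CCO3)c2cn[nH]c(=O)c12`: 7000 nM
compound 2, `O=C1c2ccccc2CN1c1cnc(NCc2c(F)ccc3c2CCO3)n2cnnc12`: 4000 nM
compound 3, `CN(C)Cc1ccc2c(c1)CN(c1cnc(NCc3c(F)ccc4c3CCO4)c3cn[nH]c(=O)c13)C2=O`: 174000 nM

In a physicochemical assay for solubility, read by LC-MS, in phosphate buffer, with a stated time of 24 h, at pH 7.4 (a lower number here means a less soluble compound, a higher number a more soluble compound), compound 1 gives 7000 nM, the second highest of the three numbers. Compound 2 gives 4000 nM, and the two lie within the usual scatter of each other. Compound 3 gives 174000 nM, which stands beyond the scatter above compound 1. Compound 4, `CNC(=O)c1ncc(-c2cnc(NCc3c(F)ccc4c3CCO4)c3cn[nH]c(=O)c23)n1C`, has not yet been measured in this assay. It differs from compound 1 in one place: 1-methyl-2-(methylcarbamoyl)-1H-imidazol-5-yl in place of 2-methyl-1H-imidazol-1-yl on an aromatic carbon. Among the compounds with values here, no step between measured compounds shows the effect of such a change in this assay, so the expectation rests on compound 1 alone. Compound 4 is expected to give 12000 nM, in the range 4000 nM to 40000 nM. The step this expectation means, a 1.7-fold higher number from compound 1 to compound 4 (0.23 log units; within the scatter), would be a small rise, near the edge of the scatter.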

Compound 4, solubility: 5000 nM
For compound 4 the middle estimate is 2.4-fold (0.38 log units) above the measured one; the range from low to high includes it.
By their numbers in this assay, from the lowest: compounds 2, 4 and 1 (each within the scatter of the next); then compound 3.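

In this assay, within the data shown here, this is the first readable step at this aromatic carbon, where 1-methyl-2-(methylcarbamoyl)-1H-imidazol-5-yl replaces 2-methyl-1H-imidazol-1-yl: a 1.4-fold lower number from compound 1 to compound 4 (0.15 log units; within the scatter). Adding a hydrogen-bond donor and four heavy atoms to the group at this position therefore leaves the number within the scatter of compound 1. Nothing available explains this outcome.

On these data alone, it remains open whether a carboxylic acid in place of the methylcarbamoyl group would give a step beyond the scatter. The compounds also leave open whether this change would give a similar step on a different core.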